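A few compounds are considered here, and "the series" means these few. Any claim that something is new, unique, unknown or untested is made for them only; others in the source may bear on it.

Compound 1 `CCCCCCC(=O)NCC(C)(C)CC1=C(O)C(=O)c2ccccc2C1=O` gives, in a functional assay on KB cells (Homo sapiens) for cytotoxicity, read by resazurin assay, with a stated time of 3 days (a higher number here means a weaker inhibitor, a lower number a stronger inhibitor), a value of 28200 nM. Compound 2 `CCCCCCCCCCCCCCCC(=O)NCC(C)(C)CC1=C(O)C(=O)c2ccccc2C1=O` carries a longer chain, and compound 2 gives 5120 nM; the step between them is a 5.5-fold lower number from compound 1 to compound 2 (0.74 log units; beyond the scatter). Compound 3 `CCCCCC(=O)OCC(C)(C)CC1=C(O)C(=O)c2ccccc2C1=O` has (pentylcarbonyl)oxy in place of (hexylcarbonyl)amino, and compound 3 gives 41000 nM; the step is a 1.5-fold higher number from compound 1 to compound 3 (0.16 log units; within the scatter). Among the three measured compounds, compound 3 carries the highest number, though compound 1 lies within the scatter of it, while compound 2 sits well below it. Compound 4 `CCCCCCCCCCCCCCCCCC(=O)OCC(C)(C)CC1=C(O)C(=O)c2ccccc2C1=O` is compound 3 with a longer chain: dodecyl in place of hydrogen on a saturated chain carbon, five bonds along the chain from a carbonyl carbon. Within the data shown here, the only measured step that resembles this, a chain lengthening on the amide side of the series, was a 5.5-fold lower number from compound 1 to compound 2 (0.74 log units; beyond the scatter), a modest lowering of the number that went beyond the scatter. The same direction and a similar size are expected here, so the expected step is a 5.5-fold lower number from compound 3 to compound 4 (0.74 log units; beyond the scatter). Compound 4 is therefore estimated at 7500 nM, with a range from 3000 nM to 20000 nM.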

Compound 4, half-maximal inhibitory concentration: 76700 nM
The estimate for compound 4 lay 10-fold (1.01 log units) below the measured number; measured number above the stated range.
By their numbers in this assay, from the lowest: compound 2; then compounds 1, 3 and 4 (each within the scatter of the next, the first and the last beyond it).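

In this assay, dodecyl in place of hydrogen on a saturated chain carbon, five bonds along the chain from a carbonyl carbon, gives a 1.9-fold higher number from compound 3 to compound 4 (0.27 log units; within the scatter), so this long addition to the ester chain leaves the number within the scatter. The lowering seen on the amide side, a 5.5-fold lower number from compound 1 to compound 2 (0.74 log units; beyond the scatter), therefore does not carry over to this ester pair, although that step added nonyl rather than dodecyl and so is not the identical change. No measurement shown here explains this difference between the two series.

From the compounds shown here alone, it remains open whether adding nonyl to the ester chain of compound 3 would lower the number as it did on the amide side. Also open, going by these compounds, is how an amine or a carboxylic acid in place of dodecyl would behave.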